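This account rests on a few compounds, and the source may have more. Where it says the series, first, only, none or still open, it means among the compounds named here.

Compound 1 `COc1ccc(/C=C/C(=O)NCCNc2ccnc3cc(Cl)ccc23)cc1` in an ADME assay on Vero cells (Chlorocebus sabaeus) for cytotoxicity, read by MTT assay, with a stated time of 72 h (on this read-out lower numbers stand for higher toxicity in this test and higher numbers for lower toxicity in this test), gives 20600 nM.
Compound 2 `COc1ccc(/C=C/C(=O)NCCNc2ccnc3cc(Cl)ccc23)cc1OC` in this assay gives 5600 nM.

Within the data shown here, compound 2 stands lowest of the two numbers measured so far. Among the measured compounds shown here, the only step on record, a 3.7-fold lower number from compound 1 to compound 2 (0.57 log units; beyond the scatter), arose from a methoxy in place of hydrogen on an aromatic carbon. Compound 3 `COc1cc(OC)c(OC)cc1/C=C/C(=O)NCCNc1ccnc2cc(Cl)ccc12` repeats that kind of change: methoxy in place of hydrogen on an aromatic carbon. Since the earlier methoxy addition gave a 3.7-fold lower number from compound 1 to compound 2 (0.57 log units; beyond the scatter), a further lowering beyond the scatter, though perhaps smaller, is expected, giving an estimated step of a 1.9-fold lower number from compound 2 to compound 3 (0.27 log units; within the scatter) in this assay. Compound 3 is therefore expected to give about 3000 nM, within a range from 1000 nM to 9000 nM.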

Compound 3, half-maximal cytotoxic concentration: 16100 nM
For compound 3 the middle estimate is 5.4-fold (0.73 log units) below the measured one, and the stated range ends below it.
By their numbers in this assay, from the lowest: compound 2; then compounds 3 and 1 (each within the scatter of the next).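

In this assay a methoxy in place of hydrogen on an aromatic carbon does not always push the number the same way: placed ortho to a large group, it gives a 2.9-fold higher number from compound 2 to compound 3 (0.46 log units; beyond the scatter), while the earlier addition gave a 3.7-fold lower number from compound 1 to compound 2 (0.57 log units; beyond the scatter). The kind of change alone therefore does not set the direction of the step in these compounds. Nothing available explains this reversal.

Whether a hydroxyl group or an amine at this same place would raise the number is open, as is what this methoxy would do on compound 1.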